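Methyl to tert-butyl on a fused five-membered ring

The compounds below may be only part of what the source reports. "The series", "measured", "known", "first", "only" and "open" are said of these compounds alone.

Compound 1 `CCN1CCc2c(c(C)nn2C(=O)Nc2ccc(Br)cc2)C1` and compound 2 `CCN1CCc2c(c(C)nn2C(=O)Nc2cccc(C(F)(F)F)c2)C1` share the same fused two-ring core; how the two differ is not broken down here. In a functional assay on the whole organism (strain Swiss albino) for inhibition, with Mus musculus as the target, in the formalin test, with a stated time of 30 min, at a dose of 100 mg/kg (a lower number here means less inhibition, a higher number more inhibition at the dose given (going by the name of the read-out)), compound 1 gives 81.6%, while compound 2 gives 23.1%, the lowest of the three numbers and beyond the scatter from both others. Compound 3 `CCN1CCc2c(c(C(C)(C)C)nn2C(=O)Nc2ccc(Br)cc2)C1` carries tert-butyl in place of methyl on an aromatic carbon on compound 1; in this assay compound 3 gives 72.1%, a change a number 9.5 percentage points lower from compound 1 to compound 3 (within the scatter).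

Compound 4 `CCN1CCc2c(c(C(C)(C)C)nn2C(=O)Nc2cccc(C(F)(F)F)c2)C1` is not yet measured. It carries the same change, (tert-butyl in place of methyl on an aromatic carbon), on compound 2, at the same place as in compound 3. The only measured case of this change stayed within the scatter, so the expectation for compound 4 rests on that single step and on the number of compound 2 alone. Compound 4 is expected to give 18% in this assay, with a range from 0% to 40%. This expected step, a number 5.1 percentage points lower from compound 2 to compound 4 (within the scatter), rests on the single measured case, a number 9.5 percentage points lower from compound 1 to compound 3 (within the scatter). Because compound 2 already gives 23.1%, there is little room below, and a number near zero is expected to be possible.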

Compound 4, a percentage reported as inhibition, in the whole organism at one dose (the size of the read-out at that dose, not a potency): 55.1%
Compound 4: the middle estimate sits 37.1 percentage points below what was measured; measured number above the stated range.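

In this assay, tert-butyl in place of methyl on an aromatic carbon gives a number 32 percentage points higher from compound 2 to compound 4 (beyond the scatter), so on the core of compound 2 this change raises the read-out clearly. The step measured on the core of compound 1 therefore does not transfer as a fixed increment, and in these two pairs the result of the change differs with the core that carries it: the same change on two cores in this assay, a number 9.5 percentage points lower (within the scatter) from compound 1 to compound 3 and a number 32 percentage points higher (beyond the scatter) from compound 2 to compound 4, 41.5 percentage points apart, beyond the scatter of two such steps. Among the compounds shown here, this shows only that the two pairs disagree; two pairs at a single dose give no general rule for other cores, no potency and no explanation of the gap.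

Still open, from the compounds shown here alone, is how a group of intermediate size at the same place, such as ethyl, isopropyl or cyclopropyl, would behave on each of the two cores. Also open, going by these compounds, is whether a polar replacement there, such as an amine or a carboxylic acid, would follow either step.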